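The compounds below may be only part of what the source reports. "The series", "measured", "known", "first", "only" and "open" are said of these compounds alone.

The measured compounds:
Compound 1, `N#Cc1c(Nc2cccc(C(F)(F)F)c2)nc(SCc2cn(Cc3ccccc3Cl)nn2)nc1-c1ccccc1`, in a functional assay on MCF7 cells (Homo sapiens) for inhibition, read by MTT assay, with a stated time of 72 h (a lower number here means a stronger inhibitor, a higher number a weaker inhibitor), compound 1 gives 12600 nM.
Compound 2, `N#Cc1c(Nc2ccccc2Cl)nc(SCc2cn(Cc3ccccc3Cl)nn2)nc1-c1ccccc1`, in this assay compound 2 gives 1950 nM.
Compound 3, `Cc1cccc(Nc2nc(SCc3cn(Cc4ccccc4Cl)nn3)nc(-c3ccccc3)c2C#N)c1`, in this assay compound 3 gives 19600 nM.

Compound 3 holds the highest number of the three. Its nearest neighbour is compound 1, the step of a 1.6-fold higher number from compound 1 to compound 3 (0.19 log units; within the scatter) lying within the scatter; its furthest is compound 2, and the step of a 10-fold higher number from compound 2 to compound 3 (1.00 log units; beyond the scatter) lies beyond it.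

Compound 4, `N#Cc1c(Nc2cccc([N+](=O)[O-])c2)nc(SCc2cn(Cc3ccccc3Cl)nn2)nc1-c1ccccc1`, differs from compound 3 by one change: nitro in place of methyl on an aromatic carbon.

Of the measured steps, the one that bears on this change is a 1.6-fold higher number from compound 1 to compound 3 (0.19 log units; within the scatter), where the group at this same place on the ring was exchanged and the number barely moved. The steps of a 6.5-fold lower number from compound 1 to compound 2 (0.81 log units; beyond the scatter) and a 10-fold higher number from compound 2 to compound 3 (1.00 log units; beyond the scatter) concern the exchange of 2-chlorophenyl for 3-(trifluoromethyl)phenyl or 3-methylphenyl, a different kind of change, and are less informative here.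

With one comparable step, and that within the scatter, the expected step of a 1.4-fold lower number from compound 3 to compound 4 (0.15 log units; within the scatter) in this assay is small, with no confident direction. Compound 4 is therefore estimated at 14000 nM in this assay, expected to fall between 5000 nM and 40000 nM.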

Compound 4, half-maximal inhibitory concentration: > 64000 nM
Compound 4: a limit, no number (the forecaster's own chance of this, stated with the estimate: 15%); middle value at least 4.5-fold (0.66 log units) from the limit.
By their numbers in this assay, from the lowest: compound 2; then compounds 1 and 3 (each within the scatter of the next). At a limit, above all of these: compound 4.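

Compound 4 stands at a limit of the assay, not at a number, in this assay: the limit of > 64000 nM in this assay, at which 1 of the 4 values shown sits. Nitro in place of methyl gives an at least 3.2-fold higher number from compound 3 to compound 4 (0.51 log units; beyond the scatter), and nitro in place of trifluoromethyl gives an at least 5.0-fold higher number from compound 1 to compound 4 (0.70 log units; beyond the scatter), so the group on this aromatic carbon can move the number beyond the scatter, which the exchange of trifluoromethyl for methyl alone had not shown. The 3-nitrophenyl in place of 2-chlorophenyl gives an at least 32-fold higher number from compound 2 to compound 4 (1.51 log units; beyond the scatter), the only step rated large among those shown, although this change alters both the group and its place on the ring.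

The compounds shown leave open how an amine, a carboxylic acid or a methoxy group on this same aromatic carbon would compare with methyl, trifluoromethyl and nitro. They also leave open whether nitro at the place that chlorine holds in compound 2 would give a number close to that of compound 2 or a limit like that of compound 4, so the group and its place on the ring cannot yet be told apart.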